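Swapping an aminophenyl for a dichlorophenyl on the carbonyl

The source may hold more compounds than are shown below. What is called first, only, known or untested is meant among the compounds shown, and "the series" means these compounds.

Among the measured compounds shown here, the two compounds measured so far share a core and differ only in the substituents on the aromatic ring attached to the pyrazole. Compound 1, `COc1ccc(-c2cc(/C=C/C(=O)c3ccc(N)cc3)[nH]n2)cc1`, carries a single methoxy group there; in a functional assay on NCI/ADR-RES cells (Homo sapiens) for cytotoxicity, read by sulforhodamine B assay, with a stated time of 48 h, tested at 100 uM (a higher number here means a weaker effect of the compound at the concentration tested, a lower number a stronger effect), compound 1 gives -38%. Compound 2, `COc1cc(-c2cc(/C=C/C(=O)c3ccc(N)cc3)[nH]n2)cc(OC)c1OC`, carries three methoxy groups; in this assay compound 2 gives -3%. Compound 2 therefore stands highest of the two numbers, and its nearest neighbour, compound 1, lies a number below it that is beyond the usual scatter of such measurements.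

The next compound, compound 3, `COc1cc(-c2cc(/C=C/C(=O)c3ccc(Cl)c(Cl)c3)[nH]n2)cc(OC)c1OC`, keeps the three methoxy groups of compound 2 and changes the other end of the molecule: 3,4-dichlorophenyl in place of 4-aminophenyl on a carbonyl carbon. For the measured compounds named here, no step of this kind between measured compounds is available, so the expectation rests on compound 2 alone. Compound 3 is estimated at -15%, with a plausible range from -50% to 20%. The step this estimate implies, a number 12 percentage points lower from compound 2 to compound 3 (beyond the scatter), is expected to be downward but small, and it may well fall within the scatter.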

Compound 3, a percentage reported as activity, at one concentration (the size of the read-out at that concentration, not a potency): 5%
For compound 3 the middle estimate is 20 percentage points below the measured one; the measured number falls inside the stated range.
By their numbers in this assay, from the lowest: compound 1; then compounds 2 and 3 (each within the scatter of the next).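

In this assay, 3,4-dichlorophenyl in place of 4-aminophenyl on a carbonyl carbon comes out at a number 8 percentage points higher from compound 2 to compound 3 (within the scatter), so this exchange, the first one shown at this end of the molecule, gives no distinguishable change in the read-out. With the three methoxy groups held constant, the 4-aminophenyl group, with its hydrogen-bond donor and acceptor, and the 3,4-dichlorophenyl group, with neither, cannot be told apart at the single concentration tested. No independent measurement bears on why the two groups read alike, and the data offer no explanation for this.

The compounds shown leave open whether the same exchange would also read alike on the single-methoxy background of compound 1, where the number printed for the 4-aminophenyl compound differs from those of compound 2 and compound 3. They also leave open how this carbonyl position would respond to other groups, such as a phenyl ring carrying a carboxylic acid or a hydroxyl, or a longer chain in place of the aromatic ring, and whether any such group would move the read-out beyond the scatter.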